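Aryl hydrazone variation at the acylhydrazone carbon: a short series

This account rests on a few compounds, and the source may have more. Where it says the series, first, only, none or still open, it means among the compounds named here.

Measured compounds:
- compound 1 `CN(C)CCn1cnnc1-c1cc(Oc2ccc(NC(=O)N/N=C/c3c[nH]c4ccccc34)cc2F)ccn1`: 820 nM
- compound 2 `CN(C)CCn1cnnc1-c1cc(Oc2ccc(NC(=O)N/N=C/c3cccc(Br)c3)cc2F)ccn1`: 970 nM
- compound 3 `CN(C)CCn1cnnc1-c1cc(Oc2ccc(NC(=O)N/N=C/c3ccc(Cl)cc3)cc2F)ccn1`: 780 nM

All three share one core and differ only in the aryl group on a carbon with a double bond to nitrogen. In a functional assay on A549 cells (Homo sapiens) for cytotoxicity, read by MTT assay, with a stated time of 72 h (a higher number here means a weaker inhibitor, a lower number a stronger inhibitor), compound 1 gives 820 nM. On the bare numbers it sits between the other two, but none of the three is separated from another beyond the scatter: a 1.2-fold higher number from compound 1 to compound 2 (0.07 log units; within the scatter), a 1.1-fold lower number from compound 1 to compound 3 (0.02 log units; within the scatter) and a 1.2-fold lower number from compound 2 to compound 3 (0.09 log units; within the scatter) are all within it. The aryl group has so far made no difference that can be read.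

Compound 4 `CN(C)CCn1cnnc1-c1cc(Oc2ccc(NC(=O)N/N=C/c3ccc(O)cc3)cc2F)ccn1` has not been measured in this assay. It differs from compound 1 in one place: 4-hydroxyphenyl in place of 1H-indol-3-yl on a carbon with a double bond to nitrogen. Of the measured steps, those bearing on it are the two that also replace 1H-indol-3-yl at the same carbon, a 1.2-fold higher number from compound 1 to compound 2 (0.07 log units; within the scatter) and a 1.1-fold lower number from compound 1 to compound 3 (0.02 log units; within the scatter), both small. Among the compounds with values here, a 4-hydroxyphenyl group has no counterpart among the measured compounds, so there is nothing to point either way beyond that.

The expectation is therefore a step no larger than the scatter, a 1.1-fold higher number from compound 1 to compound 4 (0.04 log units; within the scatter). Compound 4 is estimated at 900 nM, with a range from 400 nM to 2000 nM.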

Compound 4, half-maximal inhibitory concentration: 3560 nM
For compound 4 the middle estimate is 4.0-fold (0.60 log units) below the measured one; the measured number lies above the stated range.
By their numbers in this assay, from the lowest: compounds 3, 1 and 2 (each within the scatter of the next); then compound 4.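

The aryl group on a carbon with a double bond to nitrogen is not indifferent in this assay: 1H-indol-3-yl, 3-bromophenyl and 4-chlorophenyl could not be told apart, yet 4-hydroxyphenyl stands clear of all three, with a 4.3-fold higher number from compound 1 to compound 4 (0.64 log units; beyond the scatter) and a 3.7-fold higher number from compound 2 to compound 4 (0.56 log units; beyond the scatter) both pointing to a weaker compound. The cleanest comparison is the exchange of a single substituent, where a 4.6-fold higher number from compound 3 to compound 4 (0.66 log units; beyond the scatter) shows that the loss can follow from hydroxy in place of chloro alone, with the rest of the structure unchanged, so tolerance at this position extends to quite different aryl groups but not to every substituent on them. No measurement at hand accounts for this loss.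

Going by these compounds, whether the step belongs to the hydroxy group specifically remains open, and a methoxy, an amine or a carboxylic acid in its place on the phenyl ring would begin to show how narrow the effect is. A single hydroxyphenyl also cannot show whether 3-hydroxyphenyl would behave in the same way, or whether a hydroxy group on the indole of compound 1 would carry the same penalty.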